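Ethoxy for Ethyl on the Carboxy-Bearing Core

The source may hold more compounds than are shown below. What is called first, only, known or untested is meant among the compounds shown, and "the series" means these compounds.

Compound 1 `CCc1ccc2nc(C(=O)Nc3c(F)cc(-c4cccc(F)c4)cc3F)c(C)c(O)c2c1`: 46.3%
Compound 2 `CCOc1ccc2nc(C(=O)Nc3c(F)cc(-c4cccc(F)c4)cc3F)c(C)c(O)c2c1`: 2.03%
Compound 3 `CCc1ccc2nc(C(=O)Nc3c(F)cc(-c4cccc(F)c4)cc3F)c(C)c(C(=O)O)c2c1`: 27.2%

In a functional assay on Hep 3B2 cells (Homo sapiens) for antiproliferative activity, read by MTT assay, with a stated time of 24 h, tested at 11.11 ug/mL (on this read-out lower numbers stand for a weaker effect and higher numbers for a stronger effect at the one concentration tested), compound 3 gives 27.2%, the second highest of the three numbers. Compound 1 stands nearest to it, separated by the step of a number 19.1 percentage points lower from compound 1 to compound 3 (beyond the scatter), a modest gap beyond the scatter. Compound 2 lies furthest away, giving 2.03%, well below compound 3.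

Compound 4 `CCOc1ccc2nc(C(=O)Nc3c(F)cc(-c4cccc(F)c4)cc3F)c(C)c(C(=O)O)c2c1` differs from compound 3 by one change: ethoxy in place of ethyl on an aromatic carbon. The same change has been measured once on this core, between compound 1 and compound 2, where it produced a number 44.3 percentage points lower from compound 1 to compound 2 (beyond the scatter), a large drop. For the measured compounds named here, that single step is the only direct guide, and it points downward for compound 4 as well. Because compound 3 starts from 27.2%, a fall of the same size cannot be fully realised, and the read-out would be expected to settle near the bottom of the scale. Compound 4 is therefore expected to give 4% in this assay, within a range of 0% to 15%, which amounts to an expected step of a number 23.2 percentage points lower from compound 3 to compound 4 (beyond the scatter).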

Compound 4, a percentage reported as inhibition, at one concentration (the size of the read-out at that concentration, not a potency): 33.2%
The estimate for compound 4 lay 29.2 percentage points below the measured number; measured number outside the range, above it.
By their numbers in this assay, from the lowest: compound 2; then compounds 3 and 4 (each within the scatter of the next); then compound 1.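

With a carboxy group on the core, the change from ethyl to ethoxy no longer brings the collapse seen with hydroxy in this assay: the step is a number 6 percentage points higher from compound 3 to compound 4 (within the scatter). What this change does therefore depends on which of the two groups the core carries: the same change on two cores in this assay, a number 44.3 percentage points lower (beyond the scatter) from compound 1 to compound 2 and a number 6 percentage points higher (within the scatter) from compound 3 to compound 4, 50.3 percentage points apart, beyond the scatter of two such steps. The carboxy for hydroxy change also reverses its direction on the ethoxy pair, giving a number 31.2 percentage points higher from compound 2 to compound 4 (beyond the scatter), so the two changes cannot be read as independent: the same change on two cores in this assay, a number 19.1 percentage points lower (beyond the scatter) from compound 1 to compound 3 and a number 31.2 percentage points higher (beyond the scatter) from compound 2 to compound 4, 50.3 percentage points apart, beyond the scatter of two such steps.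

The compounds shown carry only ethyl or ethoxy at this position, so it remains open whether a longer chain such as propoxy, or an amine, would tolerate the carboxy group as ethoxy does. Going by these compounds, with a single concentration in one cell line, how these compounds compare in potency also remains open.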